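This account rests on a few compounds, and the source may have more. Where it says the series, first, only, none or still open, it means among the compounds named here.

Working notes on the series.

Compound 1 `CN(C)C(=O)c1cc2cnc(Nc3ccc(NC(=O)C4(C(=O)Nc5ccc(F)cc5)CC4)cc3)nc2n1C1CCCC1` stands highest of the two numbers recorded so far in a functional assay on SiHa cells (Homo sapiens) for inhibition, read by CCK-8 assay, with a stated time of 72 h, tested at 10 uM (on this read-out higher numbers stand for more inhibition of growth at the one concentration tested and lower numbers for less inhibition of growth), where compound 1 gives 98%. Among the measured compounds shown here, its nearest neighbour, compound 2 `CN(C)C(=O)c1cc2cnc(Nc3ccc(NC(=O)C4(C(=O)Nc5ccc(O)cc5)CC4)cc3)nc2n1C1CCCC1`, gives 94.3% in this assay; the one measured step, a number 3.7 percentage points lower from compound 1 to compound 2 (within the scatter), came with hydroxy in place of fluoro on an aromatic carbon and lies within the scatter.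

Compound 3 `CN(C)C(=O)c1cc2cnc(Nc3ccc(NC(=O)C4(C(=O)Nc5ccccc5)CC4)cc3)nc2n1C1CCCC1` is not yet measured. It differs from compound 1 by hydrogen in place of fluoro on an aromatic carbon. For the measured compounds named here, the only measured step that bears on this change is the one from compound 1 to compound 2, which removed the same fluoro in favour of hydroxy and moved the read-out by a number 3.7 percentage points lower from compound 1 to compound 2 (within the scatter). Nothing in the recorded numbers points to a shift beyond the scatter when the fluoro is instead replaced by hydrogen. The step to compound 3 is therefore expected to be a number 2 percentage points lower from compound 1 to compound 3 (within the scatter), within the scatter. Compound 3 is estimated at 96%, with a range from 88% to 100% in this assay.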

Compound 3, percent growth inhibition at one concentration: 106%
For compound 3 the middle estimate is 10 percentage points below the measured one; measured number outside the range, above it.
By their numbers in this assay, from the lowest: compounds 2, 1 and 3 (each within the scatter of the next, the first and the last beyond it).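

In this assay, hydrogen in place of fluoro gives a number 8 percentage points higher from compound 1 to compound 3 (within the scatter), so this position needs no fluoro to keep the read-out at the level of compound 1, and the phenyl and 4-fluorophenyl forms cannot be told apart here. Hydrogen in place of hydroxy gives a number 11.7 percentage points higher from compound 2 to compound 3 (beyond the scatter), a modest step and the first in the series beyond the scatter, although compound 1 lies within the scatter of both compound 2 and compound 3. No available measurement explains either step.

Open, from the compounds shown here alone, is how an amine, a carboxylic acid or a methoxy group at this same position would read in this assay. Also open, going by these compounds, is whether the gap between hydrogen and hydroxy would hold at concentrations other than the single one tested.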